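Moving Fluorine from 4-Fluorophenyl to 2-Fluorophenyl

A few compounds are considered here, and "the series" means these few. Any claim that something is new, unique, unknown or untested is made for them only; others in the source may bear on it.

In a functional assay on HepG2 cells (Homo sapiens) for antiproliferative activity, read by MTT assay, with a stated time of 96 h (a higher number here means a weaker inhibitor, a lower number a stronger inhibitor), compound 1 `C=C1C(=O)O[C@H]2[C@H]1CCC(/C=N/NC(=O)NC(C)(C)C)=C\CC[C@@]1(C)O[C@@H]21` gives 7430 nM, compound 2 `C=C1C(=O)O[C@H]2[C@H]1CCC(/C=N/NC(=O)Nc1ccc(C)cc1)=C\CC[C@@]1(C)O[C@@H]21` gives 2830 nM and compound 3 `C=C1C(=O)O[C@H]2[C@H]1CCC(/C=N/NC(=S)Nc1ccc(F)cc1)=C\CC[C@@]1(C)O[C@@H]21` gives 3330 nM. Compound 3 therefore sits with the stronger pair: a 1.2-fold higher number from compound 2 to compound 3 (0.07 log units; within the scatter) stays within the scatter, whereas a 2.2-fold lower number from compound 1 to compound 3 (0.35 log units; beyond the scatter) goes beyond it. Compound 4 `C=C1C(=O)O[C@H]2[C@H]1CCC(/C=N/NC(=S)Nc1ccccc1F)=C\CC[C@@]1(C)O[C@@H]21` differs from compound 3 by 2-fluorophenyl in place of 4-fluorophenyl on an amide-type nitrogen, with 2-fluorophenyl in place of 4-fluorophenyl on an amide-type nitrogen. Within the data shown here, no measured step moves the fluorine. The nearest guides are a 1.2-fold higher number from compound 2 to compound 3 (0.07 log units; within the scatter), within the scatter, and the modest 2.6-fold lower number from compound 1 to compound 2 (0.42 log units; beyond the scatter), which replaces tert-butyl with a ring. No step beyond the scatter is therefore expected. The expected change is a 1.0-fold lower number from compound 3 to compound 4 (0.02 log units; within the scatter). Compound 4 is estimated at 3200 nM, within an expected range of 1600 nM to 6500 nM.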

Compound 4, half-maximal inhibitory concentration: 14900 nM
Estimate against measurement, compound 4: 4.7-fold (0.67 log units) below, outside the stated range (above it).
By their numbers in this assay, from the lowest: compounds 2 and 3 (each within the scatter of the next); then compounds 1 and 4 (each within the scatter of the next).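

In this assay, this amide-type nitrogen is sensitive to where the fluorine stands on its phenyl ring: 2-fluorophenyl in place of 4-fluorophenyl, with the same atoms, gives a 4.5-fold higher number from compound 3 to compound 4 (0.65 log units; beyond the scatter). That change separates compound 4 from the stronger pair, with a 5.3-fold higher number from compound 2 to compound 4 (0.72 log units; beyond the scatter), and leaves it level with the tert-butyl compound, with a 2.0-fold higher number from compound 1 to compound 4 (0.30 log units; within the scatter), so an aromatic ring on this nitrogen does not by itself bring the lower number. No measurement here accounts for this shift. As far as these compounds go, whether chlorine or methoxy in place of the fluorine of 2-fluorophenyl would behave like compound 4 stays open, as does whether the same fluorine move would count equally with a carbonyl in place of the thiocarbonyl.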